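Swapping the imidazole arm: a lipophilicity estimate for compound 4

The source may hold more compounds than are shown below. What is called first, only, known or untested is meant among the compounds shown, and "the series" means these compounds.

Compound 1, `Cc1cc(Cl)c(-c2ncc[nH]2)cc1NC(=O)c1ccc(OCc2ccccn2)cc1`, gives > 3 in a physicochemical assay for lipophilicity (a lower number here means a more polar compound, a higher number a more lipophilic compound), which is a limit of the assay and not a number.
Compound 2, `Cc1ccc(-c2nccn2C)cc1NC(=O)c1ccc(OCc2ccccn2)cc1`, gives 2.8 in this assay.
Compound 3, `Cc1cc(C)c(-c2ncc[nH]2)cc1NC(=O)c1ccc(OCc2ccccn2)cc1`, gives 3.1 in this assay.

Among the values shown, compound 3 and compound 2 lie within the scatter of each other, so neither can be placed ahead of the other; the third value belongs to compound 1 and is a limit. For the measured compounds named here, the only measured step, a step that the limit leaves unreadable from compound 1 to compound 3, cannot be read in size, since the limit of > 3 in this assay, at which 1 of the 3 values shown sits, hides it, and it concerns a different part of the shared core anyway.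

Compound 4, `Cc1ncc(-c2cc(NC(=O)c3ccc(OCc4ccccn4)cc3)c(C)cc2C)[nH]1`, differs from compound 3 in one place: 2-methyl-1H-imidazol-5-yl in place of 1H-imidazol-2-yl on an aromatic carbon. Going by the values given here, no measured step touches this ring, so the expectation rests on the structural change alone and carries wide uncertainty. The step of a number 0.20 log units higher from compound 3 to compound 4 (within the scatter) is expected to be small, upward if anything, and to stay close to the scatter. Compound 4 is therefore estimated at 3.3 in this assay, with a range from 2.8 to 3.8.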

Compound 4, distribution coefficient: 2.8
Compound 4: middle estimate off by 0.50 log units, on the high side; the range from low to high includes it.
By their numbers in this assay, from the lowest: compounds 2, 4 and 3 (each within the scatter of the next).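

For the compounds shown here, this is the first measured change at this position, on the aromatic carbon ortho to a methyl group and para to a methyl group: 2-methyl-1H-imidazol-5-yl in place of 1H-imidazol-2-yl gives, in this assay, a number 0.30 log units lower from compound 3 to compound 4 (within the scatter). The ring here can therefore go from 5 heavy atoms to 6, with the counts of hydrogen-bond donors and acceptors unchanged, without a reading that stands apart from that of compound 3. Nothing among the measurements shown accounts for this step.

The swap adds a methyl group and moves the ring's point of attachment at once, and the compounds shown do not separate these two parts. On these data alone, how a more different group on this aromatic carbon, such as an amine or a carboxylic acid, would read in this assay stays open.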